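This account rests on a few compounds, and the source may have more. Where it says the series, first, only, none or still open, it means among the compounds named here.

In a functional assay on A549 cells (Homo sapiens) for cytotoxicity, with a stated time of 48 h (a higher number here means a weaker inhibitor, a lower number a stronger inhibitor), compound 1 (`CC(C)CC(=O)Oc1ccc2oc(/C=C/[S+](C)[O-])cc(=O)c2c1`) gives 2300 nM and compound 2 (`Cc1ccc2oc(/C=C/[S+](C)[O-])cc(=O)c2c1`) gives 1700 nM as its reading. These two readings lie within the scatter of each other (a 1.4-fold lower number from compound 1 to compound 2 (0.13 log units; within the scatter)). Compound 3 (`C[S+]([O-])/C=C/c1cc(=O)c2cc(C#N)ccc2o1`) gives only a limit of the assay (> 10000 nM) and no number.

Compound 4 (`C[S+]([O-])/C=C/c1cc(=O)c2cc(Br)ccc2o1`) has not yet been measured. It differs from compound 3 in a single group (bromo in place of cyano on an aromatic carbon), with bromo in place of cyano on an aromatic carbon of a six-membered aromatic ring of carbon only.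

Within the data shown here, two measured steps bear most directly on this change, since both bring in the same cyano group at that place (an at least 4.3-fold higher number from compound 1 to compound 3 (0.63 log units; beyond the scatter)) and (an at least 5.8-fold higher number from compound 2 to compound 3 (0.76 log units; beyond the scatter)). Going by these compounds, both lie beyond the scatter, and their true size remains open. Among the three groups tried here, only cyano fails to give a number, while methyl and (isobutylcarbonyl)oxy stay close together. On these data alone, removing cyano is therefore expected to lower the number by a modest amount, towards the readings of compound 1 and compound 2, although bromo itself is untested. The expected size of the change is an estimated step (an at least 3.3-fold lower number from compound 3 to compound 4 (0.52 log units; beyond the scatter)) towards a stronger inhibitor. Compound 4 is estimated in this assay at 3000 nM (range 1000 nM to 10000 nM).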

Compound 4, half-maximal inhibitory concentration: 1100 nM
Compound 4: middle estimate off by 2.7-fold (0.44 log units), on the high side; low and high end bracket the measured number.
By their numbers in this assay, from the lowest: compounds 4, 2 and 1 (each within the scatter of the next, the first and the last beyond it). At a limit, above all of these: compound 3.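

In this assay, going by these compounds, bromo in place of cyano on this aromatic carbon brings back a real reading (an at least 9.0-fold lower number from compound 3 to compound 4 (0.95 log units; beyond the scatter)), and the true size of this step stays open because compound 3 gives only a limit of the assay, not a number: (the limit of > 10000 nM in this assay, at which 1 of the 4 values shown sits). Bromo and methyl cannot be told apart here (a 1.5-fold lower number from compound 2 to compound 4 (0.19 log units; within the scatter)), whereas bromo and (isobutylcarbonyl)oxy do differ, though only modestly (a 2.1-fold lower number from compound 1 to compound 4 (0.32 log units; beyond the scatter)). Earlier, cyano stood against just two other groups, but a third group now gives a number in the same general range, which leaves compound 3 as the one exception among the four compounds shown.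

On these data alone, whether other halogens such as fluoro or chloro would read like bromo, and whether an amine or a carboxylic acid on this carbon would read like cyano, remains open. The compounds shown also give no reason why cyano stands apart from the other three groups, so that difference is an observation and not yet an explanation.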